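A few compounds are considered here, and "the series" means these few. Any claim that something is new, unique, unknown or untested is made for them only; others in the source may bear on it.

Compound 1 `O=C(CN(c1nc(Cl)nc2[nH]cnc12)C1CC1)N[C@@H](CC(=O)OCc1ccccc1)C(=O)OCc1ccccc1`: 12.1%
Compound 2 `CC[C@H](C)[C@H](NC(=O)CN(c1nc(Cl)nc2[nH]cnc12)C1CC1)C(=O)OCc1ccccc1`: 22%
Compound 3 `NC(=O)CC[C@H](NC(=O)CN(c1nc(Cl)nc2[nH]cnc12)C1CC1)C(=O)OCc1ccccc1`: 36%

Three compounds with a shared core were tested in a functional assay on the whole organism (Tail, strain ICR) with Mus musculus as the target, in the tail flick test, with a stated time of 120 min, at a dose of 25 umol/kg by the oral route; on this read-out lower numbers stand for a weaker effect and higher numbers for a stronger effect at the one dose given. Compound 3 stands highest of the three: the step of a number 23.9 percentage points higher from compound 1 to compound 3 (beyond the scatter) and the step of a number 14 percentage points higher from compound 2 to compound 3 (beyond the scatter) both lie beyond the scatter, whereas the step of a number 9.9 percentage points higher from compound 1 to compound 2 (within the scatter) stays within it, so compound 1 and compound 2 cannot be ordered against each other.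

Compound 4 `NC(=O)C[C@H](NC(=O)CN(c1nc(Cl)nc2[nH]cnc12)C1CC1)C(=O)OCc1ccccc1` has not yet been measured. It differs from compound 3 in one place: carbamoyl in place of carbamoylmethyl on a saturated chain carbon, two bonds along the chain from an amide-type nitrogen and a carbonyl carbon. Both measured steps that lead to compound 3 bear on this place. The step of a number 23.9 percentage points higher from compound 1 to compound 3 (beyond the scatter) replaced benzyloxycarbonyl by carbamoylmethyl there, and the step of a number 14 percentage points higher from compound 2 to compound 3 (beyond the scatter) brought in 2-carbamoylethyl for sec-butyl; each was modest and each raised the number. Neither step, however, shortens the carbamoyl-bearing chain by one carbon, so the data give no direct guide to the size of this change. The carbamoyl group itself is kept, and the expectation is a step of a number 6 percentage points lower from compound 3 to compound 4 (within the scatter) that stays within the scatter, with the number for compound 4 expected at about 30%, in a range from 16% to 44%.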

Compound 4, a percentage reported as activity, at one dose (the size of the read-out at that dose, not a potency): 15.1%
For compound 4 the middle estimate is 14.9 percentage points above the measured one, and the stated range ends above it.
By their numbers in this assay, from the lowest: compounds 1, 4 and 2 (each within the scatter of the next); then compound 3.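

In this assay, the carbamoyl group alone does not account for the higher number of compound 3 at this place on the saturated chain: cutting 2-carbamoylethyl back to carbamoylmethyl gives a number 20.9 percentage points lower from compound 3 to compound 4 (beyond the scatter), so the length of the chain that carries the group also counts. At the shorter chain, the other changes cannot be told apart from no change, with amino in place of benzyloxy on a carbonyl carbon giving a number 3 percentage points higher from compound 1 to compound 4 (within the scatter) and carbamoylmethyl in place of sec-butyl giving a number 6.9 percentage points lower from compound 2 to compound 4 (within the scatter). Nothing measured here explains why the chain length matters in this way.

The compounds shown leave open whether a longer chain bearing the carbamoyl group would raise the number further or lower it again, and whether a carboxylic acid or an amine at the end of the 2-carbamoylethyl chain could take the place of the carbamoyl group. All of these readings come from one dose at one time point, so they leave the potency of the compounds and the course of the effect over time undefined.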